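A few compounds are considered here, and "the series" means these few. Any claim that something is new, unique, unknown or untested is made for them only; others in the source may bear on it.

Among the compounds with values here, in an assay on CHO cells for displacement of a labelled ligand from 5-hydroxytryptamine receptor 7 (Homo sapiens) (on this read-out higher numbers stand for weaker inhibition and lower numbers for stronger inhibition), compound 1 `CC(C)(CCCN1CCCC(C(F)(F)F)C1)S(=O)(=O)c1ccccc1` gives 54 nM, while compound 2 `CC(C)(CCCN1CCCC(c2cnco2)C1)S(=O)(=O)c1ccccc1` gives 15 nM, the lowest of the two numbers measured so far. Within the data shown here, the only step measured, a 3.6-fold lower number from compound 1 to compound 2 (0.56 log units; beyond the scatter), put a five-membered aromatic ring where the trifluoromethyl had been. Compound 3 `CC(C)(CCCN1CCCC(c2ccccc2)C1)S(=O)(=O)c1ccccc1` differs from compound 2 by phenyl in place of 1,3-oxazol-5-yl on a saturated ring carbon. Among the measured compounds shown here, no measured step exchanges one aromatic ring for another, so that single step is only an indirect guide: it shows an aromatic group on this carbon is well tolerated. A step within the scatter is therefore expected, a 1.3-fold higher number from compound 2 to compound 3 (0.12 log units; within the scatter). Compound 3 is estimated at 20 nM, with a range from 7 nM to 60 nM.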

Compound 3, inhibition constant: 7 nM
Compound 3: middle estimate off by 2.9-fold (0.46 log units), on the high side; measured number inside the range.
By their numbers in this assay, from the lowest: compound 3; then compound 2; then compound 1.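

Exchanging one aromatic ring for another on this saturated ring carbon does change the number: phenyl, with no hydrogen-bond acceptors, gives a lower value than 1,3-oxazol-5-yl, which has two (a 2.1-fold lower number from compound 2 to compound 3 (0.33 log units; beyond the scatter)). Measured against trifluoromethyl, phenyl gives the largest step in the series (a 7.7-fold lower number from compound 1 to compound 3 (0.89 log units; beyond the scatter)). Nothing available here explains either step. Going by these compounds, whether a pyridine ring would behave more like phenyl or like 1,3-oxazol-5-yl remains open. So does the effect of adding a fluorine atom or a methoxy group to the phenyl ring.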